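Chloro for Fluoro on the Aryl Ring of Compound 3

This account rests on a few compounds, and the source may have more. Where it says the series, first, only, none or still open, it means among the compounds named here.

Measured so far, in an assay on isolated protein for inhibition of Amine oxidase [flavin-containing] B (Homo sapiens), read by fluorescence, with a stated time of 1 h; on this read-out lower numbers stand for stronger inhibition and higher numbers for weaker inhibition:
- compound 1, `c1ccc(-c2nc3ccc(N4CCCCCC4)nc3o2)cc1`: "not determined" (no result reported)
- compound 2, `Fc1cccc(-c2nc3ccc(N4CCCCC4)nc3o2)c1`: 272 nM
- compound 3, `Fc1ccc(-c2nc3ccc(N4CCCCC4)nc3s2)cc1`: 26.5 nM

Compound 1 has no result in this assay. Of the two compounds with numbers, compound 3 stands at the lower end, and its nearest neighbour is compound 2, whose number is higher, a gap beyond the usual scatter; compound 2 and compound 3 differ in more than one place, so nothing is said about any single change between them.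

The next compound is compound 4, `Clc1ccc(-c2nc3ccc(N4CCCCC4)nc3s2)cc1`. It differs from compound 3 in one place: chloro in place of fluoro on an aromatic carbon. Among the measured compounds shown here, no pair of measured compounds shows this exchange, so the step from compound 3 to compound 4 is estimated rather than read off. Compound 4 is expected to stay close to compound 3, with a step of a 1.3-fold lower number from compound 3 to compound 4 (0.12 log units; within the scatter) that may fall inside the scatter or lean toward a somewhat lower number. Compound 4 is estimated at 20 nM, in the range 7 nM to 60 nM.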

Compound 4, half-maximal inhibitory concentration: 358 nM
For compound 4 the middle estimate is 18-fold (1.25 log units) below the measured one; the whole stated range lies below it.
By their numbers in this assay, from the lowest: compound 3; then compounds 2 and 4 (each within the scatter of the next).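

In this assay, among the compounds shown here, this is the first step between compounds that differ in one place, and it shows that the aromatic carbon para to a large group is sensitive to which halogen it carries: chloro in place of fluoro gives a 14-fold higher number from compound 3 to compound 4 (1.13 log units; beyond the scatter). The counts of rings, hydrogen-bond donors, hydrogen-bond acceptors and net charge are the same for the group that leaves and the group that enters, so a step of this size arises without any difference in them. Nothing measured here accounts for the step.

Going by these compounds, it remains open whether a plain hydrogen, a methyl, a methoxy or a nitrile at this position would give a number nearer to that of compound 3 or compound 4. On these data alone, it is also open whether the same exchange would give a step of similar size on the core of compound 2.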